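Halogen swap on the aryl ring of a small ester series

A few compounds are considered here, and "the series" means these few. Any claim that something is new, unique, unknown or untested is made for them only; others in the source may bear on it.

For the measured compounds named here, in an assay for inhibition of kynurenine 3-monooxygenase (Rattus norvegicus), tested at 10 uM (on this read-out higher numbers stand for more inhibition at the one concentration tested (going by the name of the read-out) and lower numbers for less inhibition), compound 2 `COC(=O)C(=N)/C=C(\O)c1cccc(Br)c1` gives 0%, the lower of the two numbers measured so far, though within the scatter of its neighbour; compound 1 `COC(=O)C(=N)/C=C(\O)c1ccccc1` gives 3% in the same assay, and the step of a number 3 percentage points lower from compound 1 to compound 2 (within the scatter) lies within the scatter. Compound 3 `COC(=O)C(=N)/C=C(\O)c1cccc(F)c1` differs from compound 2 by fluoro in place of bromo on an aromatic carbon. Going by the values given here, the only measured step bearing on this change, a number 3 percentage points lower from compound 1 to compound 2 (within the scatter), introduced a halogen on an aromatic carbon without any shift beyond the scatter, so for compound 3 no step beyond the scatter is expected, a number 2 percentage points higher from compound 2 to compound 3 (within the scatter). Compound 3 is therefore estimated at 2%, with a range from -7% to 12%.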

Compound 3, a percentage reported as inhibition, at one concentration (the size of the read-out at that concentration, not a potency): 0%
Compound 3: the middle estimate sits 2 percentage points above what was measured; low and high end bracket the measured number.
By their numbers in this assay, from the lowest: compounds 2, 3 and 1 (each within the scatter of the next).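

The step of no change at the digits printed from compound 2 to compound 3 (within the scatter) in this assay shows that exchanging one halogen for the other at this place, meta to a group of 9 heavy atoms, moves nothing beyond the scatter. The step of a number 3 percentage points lower from compound 1 to compound 3 (within the scatter) adds that fluoro, like bromo, stays within the scatter of hydrogen, so neither halogen separates from the unsubstituted compound. No supporting evidence bears on this result. From the compounds shown here alone, whether an amine, a carboxylic acid or a methoxy group at this place would give a reading beyond the scatter stays open. So does the effect of replacing the methyl ester with an amide or a carboxylic acid on the shared core.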